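The source may report more compounds than this note shows. Statements on the series, on what has been measured and on what is new or still open speak of the compounds shown alone.

Compound 1 `CCOCC12CCC(c3nnc(-c4ccccc4C(F)(F)F)n3C)(CC1)CC2` was tested in an assay on CHO-K1 cells for inhibition of 11-beta-hydroxysteroid dehydrogenase type 2 (Mus musculus), read by scintillation proximity assay (a lower number here means a stronger inhibitor, a higher number a weaker inhibitor), where compound 1 gives > 4000 nM, a limit of the assay rather than a number. Two related compounds share that outcome. Compound 2 `CC(C)S(=O)(=O)CCC12CCC(c3nnc(-c4ccccc4C(F)(F)F)n3C)(CC1)CC2` gives > 4000 nM, also a limit. Compound 3 `CC(O)CCCC12CCC(c3nnc(-c4ccccc4C(F)(F)F)n3C)(CC1)CC2` gives > 4000 nM, again a limit. The steps between them cannot be read: a step that the two limits leave unreadable from compound 1 to compound 2, a step that the two limits leave unreadable from compound 1 to compound 3 and a step that the two limits leave unreadable from compound 2 to compound 3. All three values sit at the same point, (the limit of > 4000 nM in this assay, at which 3 of the 3 values shown sit), so compound 1 stands nowhere on a measurable scale, only at that limit.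

Compound 4 `Cn1c(-c2ccccc2C(F)(F)F)nnc1C12CCC(CCCC(C)(F)F)(CC1)CC2` has not yet been measured. It differs from compound 1 in one place: a group of 6 heavy atoms (4 carbon, 2 fluorine; no ring) in place of a group of 3 heavy atoms (2 carbon, 1 oxygen; no ring), on a saturated chain carbon bound to a saturated ring carbon. Going by the values given here, the measured steps bear on this change only in that every variation so far of the group on that saturated chain carbon bound to a saturated ring carbon has stayed at the limit, so this step is expected to be unreadable as well: a step that the limit leaves unreadable from compound 1 to compound 4. Compound 4 is therefore estimated at 8000 nM, with a range from 2500 nM to 40000 nM, and is most likely to be reported only as a limit.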

Compound 4, half-maximal inhibitory concentration: > 4000 nM
Compound 4: no number, only a limit; the forecaster's own chance of this, stated with the estimate: 85%; the middle value lies beyond the limit too.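

Compound 4 gives > 4000 nM and this is again a limit, not a number. Going by these compounds alone, no new step from compound 1, compound 2 or compound 3 to compound 4 can therefore be read: the limit of > 4000 nM in this assay, at which 4 of the 4 values shown sit. The compounds shown leave open whether in this assay any group on that saturated chain carbon bound to a saturated ring carbon gives a measurable value.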